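Methyl on the amine nitrogen: compound 3 to compound 4

The source may hold more compounds than are shown below. What is called first, only, known or untested is meant among the compounds shown, and "the series" means these compounds.

Measured compounds:
compound 1 `NCc1c[nH]c2ccc(F)cc12`: > 1000 nM
compound 2 `CCN(CC)Cc1c[nH]c2ccc(F)cc12`: > 1000 nM
compound 3 `NCCCc1c[nH]c2ccc(F)cc12`: 650 nM

In an assay on isolated protein for inhibition of Myeloperoxidase (Homo sapiens) (a higher number here means a weaker inhibitor, a lower number a stronger inhibitor), compound 1 gives > 1000 nM, which is a limit of the assay and not a number. Compound 2 likewise gives only a limit, > 1000 nM. For the measured compounds named here, compound 3 is the one compound with a number in this assay, 650 nM; the other two values shown sit at the limit of > 1000 nM in this assay, at which 2 of the 3 values shown sit. The step from compound 1 to compound 3 reads an at least 1.5-fold lower number from compound 1 to compound 3 (0.18 log units; that floor lies within the scatter), and the step from compound 2 to compound 3 reads an at least 1.5-fold lower number from compound 2 to compound 3 (0.18 log units; that floor lies within the scatter); both are floors whose size lies within the scatter. The step from compound 1 to compound 2 is a step that the two limits leave unreadable from compound 1 to compound 2.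

Compound 4 `CNCCCc1c[nH]c2ccc(F)cc12` differs from compound 3 by methyl in place of hydrogen on an amine nitrogen. Going by the values given here, the only measured step that alters the substitution on the amine nitrogen is the one from compound 1 to compound 2, and that step is unreadable, so no measured step gives a usable size for this change. The expectation for compound 4 is therefore a step of no change at the digits printed from compound 3 to compound 4 (within the scatter) in this assay, that is, no change beyond the scatter. Compound 4 is estimated at 650 nM, with a range from 250 nM to 1700 nM.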

Compound 4, half-maximal inhibitory concentration: 26 nM
Compound 4: the middle estimate sits 25-fold (1.40 log units) above what was measured; measured number outside the range, below it.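

In this assay, for the compounds shown here, the amine nitrogen proves sensitive to substitution: methyl in place of hydrogen gives a 25-fold lower number from compound 3 to compound 4 (1.40 log units; beyond the scatter), the first step in this set with a size read beyond the scatter. The other two new steps also lie beyond the scatter, with an at least 38-fold lower number from compound 1 to compound 4 (1.58 log units; beyond the scatter) and an at least 38-fold lower number from compound 2 to compound 4 (1.58 log units; beyond the scatter), and each of these changes a whole group on the saturated chain carbon bound to an aromatic carbon, not methyl alone. Compound 1 and compound 2 remain limits of the assay, which makes these two steps floors and not full sizes: the limit of > 1000 nM in this assay, at which 2 of the 4 values shown sit.

Open, as far as these compounds go, is whether the gain on this nitrogen continues with ethyl or a second methyl in place of the remaining hydrogen, or whether it is specific to a single methyl. Also open, from the compounds shown here alone, is whether methyl gives a step of this size on the amino group of compound 1, or on a longer chain than the 2-(methylamino)ethyl of compound 4.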